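Working notes: methyl for hydrogen, compound 2 to compound 3

The source may report more compounds than this note shows. Statements on the series, on what has been measured and on what is new or still open speak of the compounds shown alone.

Measured so far:
compound 1 `CC(C(=O)N1CCN(c2ccc(C(F)(F)F)cc2)CC1)N1C(=O)CCC1=O` – 25%
compound 2 `CC(C(=O)N1CCOCC1)N1C(=O)CCC1=O` – 0%

Compound 2 stands lowest of the two numbers in a functional assay on the whole organism (strain Swiss) with Mus musculus as the target, in the maximal electroshock model, with a stated time of 0.25 h, at a dose of 300 mg/kg by the intraperitoneal route; a lower number here means a weaker effect, a higher number a stronger effect of the compound at the dose given. Its nearest neighbour is compound 1, whose number in this assay lies higher by a gap beyond the usual scatter; the two structures differ in more than one place, so the two values show a gap and nothing more about its cause.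

Compound 3 `CCC(C(=O)N1CCOCC1)N1C(=O)CCC1=O` is the next compound for this assay. Compared with compound 2 it carries methyl in place of hydrogen on a saturated chain carbon, two bonds along the chain from an amide-type nitrogen in a ring and a carbonyl carbon. Among the compounds with values here, no pair among the measured compounds differs by this change alone, so there is no measured step to set the size of the expectation; the change adds a single carbon and leaves the rest of compound 2 untouched.

The expectation is therefore conservative: any step is expected to stay within the scatter, with no clear direction. Compound 3 is expected to show a step of a number 8 percentage points higher from compound 2 to compound 3 (within the scatter). For compound 3 the estimated value in this assay is 8%, within a range from 0% to 25%.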

Compound 3, a percentage reported as activity, at one dose (the size of the read-out at that dose, not a potency): 0%
Beside the measured number, compound 3's estimate is 8 percentage points above it, within the range that was stated.
By their numbers in this assay, from the lowest: compounds 2 and 3 (each within the scatter of the next); then compound 1.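

In this assay the series now has its first step that differs in one place only, running no change at the digits printed from compound 2 to compound 3 (within the scatter), for methyl in place of hydrogen on a saturated chain carbon, two bonds along the chain from an amide-type nitrogen in a ring and a carbonyl carbon. The earlier pair differed in more than one place and could show only a gap; this step shows that, on the core of compound 2, the single added carbon at this position brings no read-out into view at the dose given. No measurement shown here offers an explanation for this result.

On these data alone, whether a longer chain such as propyl, or an amine or a carboxylic acid at this same carbon, would move the number in this assay stays open. Also open, as far as these compounds go, is what the same methyl would do on the core of compound 1, which gives 25% and so leaves room for a step in either direction, something the core of compound 2 cannot show downwards.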